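Neopentyl to isopropyl on the carbonyl carbon

The compounds below may be only part of what the source reports. "The series", "measured", "known", "first", "only" and "open" are said of these compounds alone.

In an ADME assay (liver) for metabolic stability, with Liver microsome (Rattus norvegicus) as the target, read by LC-MS, using microsomes and NADPH, with stated times of 5 min and 60 min, tested at 4 uM (a higher number here means that more of the compound is left, a lower number that less of the compound is left), compound 1 `Cc1c(OCCCCOc2ccc(F)c(C(=O)O)c2)ccc(C(=O)CC(C)(C)C)c1O` gives 58%, compound 2 `Cc1c(OCCCCOc2ccc(C(=O)CC(C)(C)C)c(O)c2C)cccc1C(=O)O` gives 51% and compound 3 `Cc1c(OCCCCOc2cccc(C(=O)O)c2)ccc(C(=O)CC(C)C)c1O` gives 51%. Compound 1 stands level with the other two: its gaps to both lie within the scatter, so the three values form no order.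

Compound 4 `Cc1c(OCCCCOc2ccc(F)c(C(=O)O)c2)ccc(C(=O)C(C)C)c1O` is the next to be read. It differs from compound 1 in one place, with isopropyl in place of neopentyl on a carbonyl carbon.

Going by the values given here, only one measured step bears on this, and only indirectly. The step of a number 7 percentage points lower from compound 1 to compound 2 (within the scatter) lies within the scatter, and it replaces 3-carboxy-4-fluorophenyl on an oxygen on a saturated carbon, not the group on the carbonyl carbon. Among the compounds with values here, compound 3 differs from compound 1 in more than one place and supplies no single step. Within the data shown here, no measured step therefore tests the present change directly.

With that gap in mind, the expectation stays close to compound 1 at 58%, with no step beyond the scatter in this assay and no firm direction. The expected change is a number 4 percentage points lower from compound 1 to compound 4 (within the scatter), an estimate that remains within the scatter. For compound 4 the estimated value is 54%, with an expected range of 40% to 68%.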

Compound 4, percent of the compound remaining: 60%
For compound 4 the middle estimate is 6 percentage points below the measured one; low and high end bracket the measured number.
By their numbers in this assay, from the lowest: compounds 2, 3, 1 and 4 (each within the scatter of the next).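

In this assay the first single-place test of the group on the carbonyl carbon reads as a number 2 percentage points higher from compound 1 to compound 4 (within the scatter), so exchanging neopentyl for isopropyl, a drop from 5 heavy atoms to 3, leaves compound 4 level with compound 1. Going by these compounds alone, the only earlier single-place step concerned the 3-carboxy-4-fluorophenyl group on the oxygen, so this position now has a reading of its own, and within this pair the smaller carbon group brings no change beyond the scatter. Nothing measured here offers an explanation for this level result.

Two branched carbon groups on one core cannot show whether the position would stay level with a different kind of group, such as a cyclohexyl ring, a longer straight chain or an amine on the carbonyl carbon. Also open, as far as these compounds go, is whether isopropyl in place of neopentyl would read the same way with the 3-carboxy-2-methylphenyl group of compound 2 on the oxygen.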